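An Aryl Swap in a Series Without Spread

A few compounds are considered here, and "the series" means these few. Any claim that something is new, unique, unknown or untested is made for them only; others in the source may bear on it.

In a functional assay, read by spectrophotometry, tested at 100 uM (on this read-out lower numbers stand for stronger inhibition and higher numbers for weaker inhibition), compound 3 `O=C(/C=C/c1cccs1)c1cccc(NC(=O)c2cc(-c3ccncc3)n[nH]2)c1` gives 70000 nM and so lies within the scatter of both other measured compounds. Compound 1 `O=C(/C=C/c1cccc2ccccc12)c1cccc(NC(=O)c2cc(-c3ccncc3)n[nH]2)c1` reads 72100 nM on this scale, and compound 2 `O=C(/C=C/c1ccc(Cl)cc1)c1cccc(NC(=O)c2cc(-c3ccncc3)n[nH]2)c1` reads 78900 nM on it too.

The step to compound 4 `CN(C)c1ccc(/C=C/C(=O)c2cccc(NC(=O)c3cc(-c4ccncc4)n[nH]3)c2)cc1` is 4-(dimethylamino)phenyl in place of thiophen-2-yl on a double-bonded chain carbon bound to a double-bonded chain carbon and puts 4-(dimethylamino)phenyl in place of thiophen-2-yl on a double-bonded chain carbon bound to a double-bonded chain carbon. The measured steps that bear on it replace the group at that same place, namely a 1.1-fold higher number from compound 1 to compound 2 (0.04 log units; within the scatter) and a 1.0-fold lower number from compound 1 to compound 3 (0.01 log units; within the scatter) and a 1.1-fold lower number from compound 2 to compound 3 (0.05 log units; within the scatter), none of them beyond the scatter. Among the compounds with values here, no measured compound carries the entering group, so this evidence is indirect. Resting on those small steps, no change beyond the scatter is expected in this assay in either direction. The estimated step is a 1.0-fold higher number from compound 3 to compound 4 (0.01 log units; within the scatter) in size. For compound 4 the estimated value is 72000 nM, with an expected range from 38000 nM to 120000 nM as its limits.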

Compound 4, half-maximal inhibitory concentration: 60900 nM
Compound 4: middle estimate off by 1.2-fold (0.07 log units), on the high side; low and high end bracket the measured number.
By their numbers in this assay, from the lowest: compounds 4, 3, 1 and 2 (each within the scatter of the next).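

The place on a double-bonded chain carbon bound to a double-bonded chain carbon now holds a fourth aromatic group, 4-(dimethylamino)phenyl, and in this assay the number still stays within the scatter of the thiophen-2-yl and naphthalen-1-yl compounds (a 1.1-fold lower number from compound 3 to compound 4 (0.06 log units; within the scatter); a 1.2-fold lower number from compound 1 to compound 4 (0.07 log units; within the scatter)). Dimethylamino in place of chloro on an aromatic carbon also gives no step beyond the scatter (a 1.3-fold lower number from compound 2 to compound 4 (0.11 log units; within the scatter)), so the four aromatic groups shown cannot be told apart in this assay. No other data bear on this result.

The compounds shown leave open whether a non-aromatic group at this place, such as cyclohexyl or a carboxylic acid, would shift the number beyond the scatter. They also leave open whether any change to the shared core would do so.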